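The compounds below may be only part of what the source reports. "The series", "measured", "known", "first", "only" and "open" are said of these compounds alone.

Measured so far:
compound 1 `O=C1CC(c2ccccc2Br)C(=O)N1CN1CCN(c2ccccc2)CC1` — 100 mg/kg
compound 2 `O=C1CC(c2ccccc2Br)C(=O)N1CN1CCN(c2ccc(F)cc2)CC1` — 100 mg/kg
compound 3 `O=C1CC(c2ccccc2Br)C(=O)N1CN1CCN(c2cccc(Cl)c2)CC1` — 100 mg/kg

In a functional assay on the whole organism (strain CF-1 albino) with Mus musculus as the target, with a stated time of 4 h (on this read-out lower numbers stand for an effect already at smaller amounts and higher numbers for an effect only at larger amounts of compound), compound 3 gives 100 mg/kg, level with compound 1 and compound 2 at the digits shown; none of the three can be ranked against the others. The measured steps all stay flat: no change at the digits printed from compound 1 to compound 2 (within the scatter), no change at the digits printed from compound 1 to compound 3 (within the scatter), no change at the digits printed from compound 2 to compound 3 (within the scatter). Compound 4 `O=C1CC(c2ccccc2Br)C(=O)N1CN1CCN(c2ccc(Cl)cc2)CC1` differs from compound 3 only on the amine nitrogen in the ring: 4-chlorophenyl in place of 3-chlorophenyl on an amine nitrogen in a ring. The steps of no change at the digits printed from compound 1 to compound 3 (within the scatter) and no change at the digits printed from compound 2 to compound 3 (within the scatter) bear on this change most directly, and both lie within the scatter, so no step beyond the scatter is expected in this assay. Compound 4 is therefore estimated at 100 mg/kg, with a range of 50 mg/kg to 200 mg/kg, which means an expected step of no change at the digits printed from compound 3 to compound 4 (within the scatter).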

Compound 4, minimum effective dose: 300 mg/kg
Compound 4: middle estimate off by 3.0-fold (0.48 log units), on the low side, and the stated range ends below it.
By their numbers in this assay, from the lowest: compounds 1, 2 and 3 (each within the scatter of the next); then compound 4.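

In this assay, the same atoms joined differently are enough to move the number: with 4-chlorophenyl in place of 3-chlorophenyl on the amine nitrogen in a ring, there is a 3.0-fold higher number from compound 3 to compound 4 (0.48 log units; beyond the scatter) as the step. The group on that aromatic carbon also matters here, since chloro in place of fluoro gives a 3.0-fold higher number from compound 2 to compound 4 (0.48 log units; beyond the scatter) and chloro in place of hydrogen gives a 3.0-fold higher number from compound 1 to compound 4 (0.48 log units; beyond the scatter), whereas compound 1 and compound 2 stayed level. Nothing in the data available accounts for this shift. Going by these compounds, whether a methyl, methoxy or trifluoromethyl group on the same carbon would track with compound 4 or with compound 2 remains open.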